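A few compounds are considered here, and "the series" means these few. Any claim that something is new, unique, unknown or untested is made for them only; others in the source may bear on it.

Going by the values given here, compound 3 `COc1cc(CNC(=S)NCC(COC(=O)C(C)(C)C)Cc2ccc(C)c(C)c2)cc(Br)c1O` gives in an assay on CHO cells for displacement of a labelled ligand from transient receptor potential cation channel subfamily V member 1 (Rattus norvegicus) (on this read-out higher numbers stand for weaker inhibition and lower numbers for stronger inhibition), a value of 33.1 nM, the second highest of the three numbers measured so far, though all three lie within the scatter of one another. Its nearest neighbour is compound 2 `COc1cc(CNC(=S)NCC(COC(=O)C(C)(C)C)Cc2ccc(C)c(C)c2)cc(Cl)c1O`, which gives 30.9 nM in this assay, and the furthest is compound 1 `COc1cc(CNC(=S)NC(CCc2ccc(C(C)(C)C)cc2)COC(=O)C(C)(C)C)ccc1O`, which gives 36.5 nM, so on these numbers none of the three can be told apart. Compound 4 `COc1cc(CNC(=S)NCC(COC(=O)C(C)(C)C)Cc2ccc(C)c(C)c2)cc(I)c1O` differs from compound 3 in one place: iodo in place of bromo on an aromatic carbon. Among the compounds with values here, one measured step bears on this exchange of a halogen for the next heavier halogen on an aromatic carbon: a 1.1-fold higher number from compound 2 to compound 3 (0.03 log units; within the scatter), bromo in place of chloro, which stayed within the scatter. Going one halogen further is therefore expected to give no step beyond the scatter, and the expected outcome is a 1.1-fold higher number from compound 3 to compound 4 (0.02 log units; within the scatter). For compound 4 the value expected in this assay is 35 nM, with a range from 17 nM to 75 nM.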

Compound 4, inhibition constant: 232 nM
For compound 4 the middle estimate is 6.6-fold (0.82 log units) below the measured one, and the stated range ends below it.
By their numbers in this assay, from the lowest: compounds 2, 3 and 1 (each within the scatter of the next); then compound 4.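

At this place on the ring, ortho to the hydroxy group, moving to the next heavier halogen is not a uniform step: in this assay, iodo brings a 7.0-fold higher number from compound 3 to compound 4 (0.85 log units; beyond the scatter) and a 7.5-fold higher number from compound 2 to compound 4 (0.88 log units; beyond the scatter), whereas chloro and bromo cannot be told apart. The earlier pair therefore gave no warning of a sharp change: inhibition holds with chloro and bromo at this position, then weakens beyond the scatter with iodo. Nothing available here accounts for this change.

On these data alone, whether fluoro, or a plain hydrogen with no halogen, would behave like chloro and bromo or like iodo remains open, as does the result for a methyl or nitrile group here. Also open, as far as these compounds go, is whether iodo would bring a step of similar size on a different side chain.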